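This account rests on a few compounds, and the source may have more. Where it says the series, first, only, none or still open, it means among the compounds named here.

Compound 1 `CC(C)C(NC(=O)NO)C(=O)NC1CCCCC1` gives in a functional assay on CCRF-CEM cells (Homo sapiens) for inhibition (on this read-out higher numbers stand for weaker inhibition and lower numbers for stronger inhibition), only a limit of the assay, > 100000 nM. Compound 2 `CCC(C)C(NC(=O)NO)C(=O)NC1CCCCC1` gives in this assay a value of 153000 nM. Compound 3 `CC(C)C(NC(=O)n1nnc2ccccc21)C(=O)NC1CCCC1` also gives only a limit in this assay, > 200000 nM.

The change from compound 1 to compound 2 is methyl in place of hydrogen on a saturated chain carbon, three bonds along the chain from an amide-type nitrogen and a carbonyl carbon. Its step in this assay is a step that the limit leaves unreadable from compound 1 to compound 2, which cannot be read as a size since compound 1 sits at the limit of > 100000 nM in this assay, at which 1 of the 3 values shown sits. The same change is now made from compound 3 to compound 4 `CCC(C)C(NC(=O)n1nnc2ccccc21)C(=O)NC1CCCC1`: methyl in place of hydrogen on a saturated chain carbon, three bonds along the chain from an amide-type nitrogen and a carbonyl carbon. The place of the change is the same in both pairs. How the core of compound 1 and the core of compound 3 differ is not broken down here.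

Compound 3 sits at the limit of > 200000 nM in this assay, at which 1 of the 3 values shown sits, so the step to compound 4 starts from a limit. Compound 4 is expected to stay weak in this assay, with an estimated step that the limit leaves unreadable from compound 3 to compound 4, because the same change gave no readable gain in a step that the limit leaves unreadable from compound 1 to compound 2. The estimate for compound 4 in this assay is 250000 nM, ranging from 120000 nM to 600000 nM, most likely reported only as a limit.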

Compound 4, half-maximal inhibitory concentration: 116000 nM
For compound 4 the middle estimate is 2.2-fold (0.33 log units) above the measured one; measured number below the stated range.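

In this assay, methyl in place of hydrogen, which turns isopropyl into sec-butyl, gives an at least 1.7-fold lower number from compound 3 to compound 4 (0.23 log units; that floor lies within the scatter). Compound 3 is only a limit, not a number: the limit of > 200000 nM in this assay, at which 1 of the 4 values shown sits.

The step from compound 1 to compound 2 cannot be read; in both pairs the sec-butyl compound carries a measured value and the isopropyl compound only a limit, but with no two step sizes to set side by side, the data do not show that the change does the same on both cores.

The compounds shown leave open what a longer chain, or an amine on that chain, would do at this place on either core in this assay. They also leave open how the core of compound 1 and the core of compound 3 compare on their own, as no pair shown differs in that part alone.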